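This account rests on a few compounds, and the source may have more. Where it says the series, first, only, none or still open, it means among the compounds named here.

Measured in a functional assay on DU-145 cells (Homo sapiens) for antiproliferative activity, read by sulforhodamine B assay, with a stated time of 3 days; a higher number here means a weaker inhibitor of growth, a lower number a stronger inhibitor of growth:
- compound 1 `O=C(Nc1ccccn1)c1cccc(Nc2ncc(F)c(Nc3ccc(F)cc3)n2)c1`: 15100 nM
- compound 2 `O=C(Nc1cccc(Nc2ncc(F)c(Nc3ccc(F)cc3)n2)c1)c1cnccn1`: 26400 nM
- compound 3 `O=C(Nc1cccc(Nc2ncc(F)c(Nc3ccc(F)cc3)n2)c1)c1cccc([N+](=O)[O-])c1`: 12600 nM

Compound 3 and compound 1 lie within the scatter of each other, and only compound 2 stands apart from compound 3, as the step below shows.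

The next change leads to compound 4 `CN1CCC(C(=O)Nc2cccc(Nc3ncc(F)c(Nc4ccc(F)cc4)n3)c2)CC1`: 1-methylpiperidin-4-yl in place of 3-nitrophenyl on a carbonyl carbon. In words, 1-methylpiperidin-4-yl replaces 3-nitrophenyl on a carbonyl carbon.

Within the data shown here, two measured steps bear on this, though only indirectly: a 1.7-fold higher number from compound 1 to compound 2 (0.24 log units; within the scatter), and a 2.1-fold lower number from compound 2 to compound 3 (0.32 log units; beyond the scatter). Both exchange one aromatic group for another. Among the measured compounds shown here, none of the measured compounds has a non-aromatic ring in this region, so the direction of the change is unknown.

Changes on this side of the core have moved this assay only slightly so far, so no shift beyond the scatter is expected, and the estimated step is a 1.1-fold higher number from compound 3 to compound 4 (0.05 log units; within the scatter). The range is kept wide, since this is a new type of group. For compound 4 the expected value is 14000 nM, with an estimated range of 5000 nM to 35000 nM.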

Compound 4, concentration for 50% growth inhibition: 1150 nM
Compound 4: middle estimate off by 12-fold (1.09 log units), on the high side; measured number below the stated range.
By their numbers in this assay, from the lowest: compound 4; then compounds 3, 1 and 2 (each within the scatter of the next, the first and the last beyond it).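

In this assay this place on the carbonyl carbon proves far more responsive than the aromatic exchanges indicated, with 1-methylpiperidin-4-yl giving an 11-fold lower number from compound 3 to compound 4 (1.04 log units; beyond the scatter) and a 23-fold lower number from compound 2 to compound 4 (1.36 log units; beyond the scatter) in exchanges at that same carbon. The comparison with the reversed amide, which replaces the whole amide unit, points the same way, with a 13-fold lower number from compound 1 to compound 4 (1.12 log units; beyond the scatter) as its result. Compound 4 is thus the only compound shown with a non-aromatic ring here, and its number lies beyond the scatter of all three aromatic compounds, though no measurement available here accounts for the gain.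

The compounds shown leave open whether the gain follows the ring nitrogen or the saturated ring itself. A cyclohexyl group, an unmethylated piperidin-4-yl and an open-chain dimethylaminoethyl group would separate these readings.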